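The source may hold more compounds than are shown below. What is called first, only, known or untested is meant among the compounds shown, and "the series" means these compounds.

Compound 1, `O=C(CCc1ccc(C(F)(F)F)cc1)Nc1ccc2nc(N3CCCC3)ccc2c1`, and compound 2, `O=C(CCc1ccc(C(F)(F)F)cc1)Nc1ccc2nc(N3CC4CCC3CC4)ccc2c1`, share an amide-linked core and differ only in the amine on the ring carbon next to the ring nitrogen. In an assay on isolated protein for displacement of a labelled ligand from melanin-concentrating hormone receptor 1 (Homo sapiens) (on this read-out lower numbers stand for stronger inhibition and higher numbers for weaker inhibition), compound 1 gives 3 nM; 3 nM (2 entries) and compound 2 gives 3 nM. Compound 3, `O=C(CCc1ccc(C(F)(F)F)cc1)Nc1ccc2nc(N3CCCCCC3)ccc2c1`, carries azepan-1-yl at that carbon and gives 36 nM in this assay, the highest number of the two single entries; the step of a 12-fold higher number from compound 2 to compound 3 (1.08 log units; beyond the scatter) is the only one that bears on a change at this position. Compound 4, `CCN(CC)c1ccc2cc(NC(=O)CCc3ccc(C(F)(F)F)cc3)ccc2n1`, brings (diethylamino in place of azepan-1-yl on an aromatic carbon). Within the data shown here, no measured step replaces a ring there with an open chain, so his expectation rests on the spread seen from compound 2 to compound 3: he estimates a moderate fall, a 3.0-fold lower number from compound 3 to compound 4 (0.48 log units; beyond the scatter), and puts compound 4 at 12 nM, expected within 3 nM to 50 nM.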

Compound 4, half-maximal inhibitory concentration: 88 nM
The estimate for compound 4 lay 7.3-fold (0.87 log units) below the measured number; measured number outside the range, above it.
By their numbers in this assay, from the lowest: compound 2; then compound 3; then compound 4.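

In this assay, replacing the azepan-1-yl ring with the open diethylamino chain gives a 2.4-fold higher number from compound 3 to compound 4 (0.39 log units; beyond the scatter) and so weakens inhibition further, although the step is modest. Measured against the bridged ring of compound 2, the same open chain gives a 29-fold higher number from compound 2 to compound 4 (1.47 log units; beyond the scatter), which places compound 4 highest of the three single values. Nothing available here accounts for either step. Going by these compounds, whether a shorter open chain such as dimethylamino would stay close to compound 4 remains open, as does where a six-membered piperidin-1-yl or morpholin-4-yl ring would fall.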